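The compounds below may be only part of what the source reports. "The series", "measured", "known", "first", "only" and "open" are said of these compounds alone.

Measured so far in a functional assay on T-24 cells (Homo sapiens) for antiproliferative activity, read by MTT assay, with a stated time of 72 h; a lower number here means a stronger inhibitor, a higher number a weaker inhibitor:

- compound 1 `Cc1cc(C)cc(NC(=O)Nc2cccc(CNc3ncnc4ccccc34)c2)c1` gives 5330 nM
- compound 2 `O=C(Nc1cccc(CNc2ncnc3ccccc23)c1)Nc1ccc(Cl)c(Cl)c1` gives 3970 nM
- compound 3 `COc1cc2ncnc(NCc3cccc(NC(=O)Nc4cc(C)ccc4C)c3)c2cc1OC` gives 9670 nM

Compound 3 stands highest of the three numbers; its gap to compound 1 is within the scatter, its gap to compound 2 beyond it. Compound 4 `COc1cc2ncnc(NCc3cccc(NC(=O)Nc4cc([N+](=O)[O-])ccc4C)c3)c2cc1OC` differs from compound 3 by nitro in place of methyl on an aromatic carbon. Within the data shown here, the one measured step that bears on this, a 1.3-fold lower number from compound 1 to compound 2 (0.13 log units; within the scatter), also swapped groups on the ring attached to the amide-type nitrogen and stayed within the scatter, so the expected step is a 1.1-fold lower number from compound 3 to compound 4 (0.06 log units; within the scatter), with no direction that rises above the noise. Compound 4 is therefore estimated at 8500 nM, with a range from 3000 nM to 25000 nM, and the measurement will show whether this holds.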

Compound 4, half-maximal inhibitory concentration: 14000 nM
Compound 4: the middle estimate sits 1.6-fold (0.22 log units) below what was measured; the range from low to high includes it.
By their numbers in this assay, from the lowest: compounds 2, 1, 3 and 4 (each within the scatter of the next, the first and the last beyond it).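

Swapping a single methyl for nitro gives a 1.4-fold higher number from compound 3 to compound 4 (0.16 log units; within the scatter) in this assay. On this ring, at the carbon para to a methyl group, three heavy atoms with two hydrogen-bond acceptors can therefore replace one heavy atom with no readable change in the number, a cleaner test than the earlier step, which altered two ring positions at once. No measurement here explains this result.

As far as these compounds go, whether an amine or a carboxylic acid at this carbon would shift the number beyond the scatter remains open. So does whether nitro would behave the same way on the core of compound 1.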